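A few compounds are considered here, and "the series" means these few. Any claim that something is new, unique, unknown or untested is made for them only; others in the source may bear on it.

Working notes on the series. Compound 3 `CN(c1ccc2[nH]c(-c3n[nH]c4ccccc34)cc2n1)S(=O)(=O)c1ccc(Cl)cc1`, compound 1 `CN(C(=O)c1ccc(F)cc1)c1ccc2[nH]c(-c3n[nH]c4ccccc34)cc2n1` and compound 2 `COc1ccc(C(=O)N(C)c2ccc3[nH]c(-c4n[nH]c5ccccc45)cc3n2)cc1` share one core and differ only in the outer group on a nitrogen on an aromatic ring. In a functional assay on KB cells (Homo sapiens) for antiproliferative activity, read by MTT assay, with a stated time of 72 h (a higher number here means a weaker inhibitor, a lower number a stronger inhibitor), compound 1 gives 7220 nM, compound 2 gives 12900 nM, and compound 3 gives 8350 nM. On these numbers compound 3 is indistinguishable from the other two: the nearest number is that of compound 1, the furthest that of compound 2, both within the scatter. Compound 4 `CN(c1ccc2[nH]c(-c3n[nH]c4ccccc34)cc2n1)S(=O)(=O)c1ccc(OC(F)(F)F)cc1` has not yet been measured in this assay. It differs from compound 3 in one place: trifluoromethoxy in place of chloro on an aromatic carbon. The step that bears most directly on this change, a swap of the group on an aromatic carbon of the outer ring, is a 1.8-fold higher number from compound 1 to compound 2 (0.25 log units; within the scatter), and it stayed within the scatter. The two steps that exchange the whole outer group, a 1.2-fold higher number from compound 1 to compound 3 (0.06 log units; within the scatter) and a 1.5-fold lower number from compound 2 to compound 3 (0.19 log units; within the scatter), also stayed within it. No change in that part of the molecule has so far moved the number beyond the scatter, so for compound 4 the expected step in this assay is a 1.0-fold lower number from compound 3 to compound 4 (0.02 log units; within the scatter), in no direction beyond the scatter. Compound 4 is therefore estimated at 8000 nM in this assay, with a range from 3000 nM to 22000 nM.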

Compound 4, half-maximal inhibitory concentration: 1330 nM
For compound 4 the middle estimate is 6.0-fold (0.78 log units) above the measured one, outside the stated range (below it).
By their numbers in this assay, from the lowest: compound 4; then compounds 1, 3 and 2 (each within the scatter of the next).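

In this assay, going by these compounds alone, the exchange of chloro for trifluoromethoxy on a six-membered aromatic ring of carbon only, para to a large group, gives a 6.3-fold lower number from compound 3 to compound 4 (0.80 log units; beyond the scatter) and is the only step printed as beyond the scatter. Within the data shown here, this shows that the outer ring of the sulfonyl compounds is not as flat a region as the earlier compounds suggested: the one earlier swap on an outer-ring carbon, a 1.8-fold higher number from compound 1 to compound 2 (0.25 log units; within the scatter) on the carbonyl-linked ring, stayed within the scatter, and so did both exchanges of the whole outer group. Nothing on hand accounts for the size of this step, which for now is an observation about one pair of compounds, with no measured property to explain it.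

From the compounds shown here alone, whether the step belongs to trifluoromethoxy in particular remains open, since a single pair cannot show how other groups on this carbon, such as trifluoromethyl, a nitrile or an amine, would read. Also open, going by these compounds, is whether trifluoromethoxy on the carbonyl-linked outer ring of compound 1 would give a step of similar size, or whether this one depends on the sulfonyl link.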